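The compounds below may be only part of what the source reports. "The series", "measured", "known", "first", "only" and "open" are said of these compounds alone.

Measured in an ADME assay on microsomes (Mus musculus) for metabolic stability; a higher number here means faster removal of the compound, a lower number slower removal:
- compound 1 `CNC(=O)[C@@H]1CCCN1S(=O)(=O)c1ccc(Cl)c(COc2cccc3c(-n4ccnc4)cc(C)nc23)c1Cl`: 267 mL/min/kg
- compound 2 `CNC(=O)[C@@H]1CCCN1S(=O)(=O)c1ccc(Cl)c(COc2cccc3c(C(F)(F)F)cc(C)nc23)c1Cl`: 1380 mL/min/kg
- compound 3 `Cc1cc(C(F)(F)F)c2cccc(OCc3c(Cl)ccc(S(=O)(=O)N4CC[C@@H](N(C)C)C4)c3Cl)c2n1`: 867 mL/min/kg

Compound 3, at 867 mL/min/kg, lies within the scatter of compound 2 and has a higher number than compound 1. Compound 4 `Cc1cc(C(F)(F)F)c2cccc(OCc3c(Cl)ccc(S(=O)(=O)N4CCC(C#N)CC4)c3Cl)c2n1` carries 4-cyanopiperidin-1-yl in place of 3-(dimethylamino)pyrrolidin-1-yl on a sulfonyl sulfur. For the measured compounds named here, the one measured change at this place is a 1.6-fold lower number from compound 2 to compound 3 (0.20 log units; within the scatter), so a swap here has so far moved this assay very little. The larger 5.2-fold higher number from compound 1 to compound 2 (0.71 log units; beyond the scatter) arose on an aromatic carbon and does not bear on this change. No step beyond the scatter is therefore expected, and the expected step is a 1.1-fold lower number from compound 3 to compound 4 (0.03 log units; within the scatter). Compound 4 is estimated at 800 mL/min/kg, with an expected range of 400 mL/min/kg to 1500 mL/min/kg.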

Compound 4, clearance: 1720 mL/min/kg
Beside the measured number, compound 4's estimate is 2.2-fold (0.33 log units) below it; measured number above the stated range.
By their numbers in this assay, from the lowest: compound 1; then compounds 3, 2 and 4 (each within the scatter of the next).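

In this assay, 4-cyanopiperidin-1-yl on the sulfonyl sulfur gives a 2.0-fold higher number from compound 3 to compound 4 (0.30 log units; within the scatter) and a 1.2-fold higher number from compound 2 to compound 4 (0.10 log units; within the scatter) in comparison with the other two groups at this place. All three groups therefore stand within the scatter of one another, even though the ring size and the substituent both differ. Nothing shown explains these numbers.

From the compounds shown here alone, it remains open whether a carboxylic acid or a morpholin-4-yl group on the sulfonyl sulfur would give a step beyond the scatter. Going by these compounds, it is also open whether 1H-imidazol-1-yl on the aromatic carbon would still go with a lower number when 4-cyanopiperidin-1-yl is present.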